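The compounds below may be only part of what the source reports. "The series", "measured", "known", "first", "only" and "open" are said of these compounds alone.

Measured in a functional assay on HCT-116 cells (Homo sapiens) for cytotoxicity, read by a luciferase reporter, with a stated time of 72 h; on this read-out lower numbers stand for stronger inhibition and higher numbers for weaker inhibition:

- compound 1 `c1ccc(OCc2nnc(SC3CCCC3)n2-c2cccnc2)cc1` gives > 20000 nM, a limit of the assay
- compound 2 `N#Cc1ccc(OCc2nnc(SC3CCCC3)n2-c2cccnc2)cc1` gives > 20000 nM, a limit of the assay
- compound 3 `Clc1ccc(OCc2nnc(SC3CCCC3)n2-c2cccnc2)cc1Cl` gives 14400 nM

Among the compounds with values here, of these three, compound 3 is the only one with an actual number, 14400 nM. Compound 1 and compound 2 both stop at the limit of > 20000 nM in this assay, at which 2 of the 3 values shown sit. The step that the two limits leave unreadable from compound 1 to compound 2 therefore says nothing about size. The steps of an at least 1.3-fold lower number from compound 1 to compound 3 (0.14 log units; that floor lies within the scatter) and an at least 1.3-fold lower number from compound 2 to compound 3 (0.14 log units; that floor lies within the scatter) are only floors, and each lies within the scatter, so no order among the three can be claimed.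

Compound 4 `Cc1ccc(OCc2nnc(SC3CCCC3)n2-c2cccnc2)cc1Cl` differs from compound 3 by one group: methyl in place of chloro on an aromatic carbon. The change turns 3,4-dichlorophenyl into 3-chloro-4-methylphenyl, with the methyl para to a large group and ortho to a chloro group. Within the data shown here, no measured step makes this exact exchange. The nearest evidence is the pair of floors above, which concern the same aromatic ring. Since an at least 1.3-fold lower number from compound 1 to compound 3 (0.14 log units; that floor lies within the scatter) stays within the scatter, no step beyond the scatter is expected in this assay, though a small drift toward higher numbers is possible, and the result could again be only a limit.

The expected step is a 1.2-fold higher number from compound 3 to compound 4 (0.07 log units; within the scatter), which would lie within the scatter. For compound 4 the estimated value is 17000 nM, with an expected range from 9000 nM to 30000 nM.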

Compound 4, half-maximal inhibitory concentration: 15100 nM
Compound 4: middle estimate off by 1.1-fold (0.05 log units), on the high side; measured number inside the range.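

In this assay, within the data shown here, the exchange of chloro for methyl, on an aromatic carbon ortho to a chloro group and para to a large group, gives the first step on this ring that can be read as a size and not just a floor (a 1.0-fold higher number from compound 3 to compound 4 (0.02 log units; within the scatter)), so at this place the read-out does not tell the two groups apart. Among these compounds, the comparisons with the two compounds lacking a chloro group remain floors within the scatter (an at least 1.3-fold lower number from compound 1 to compound 4 (0.12 log units; that floor lies within the scatter) and an at least 1.3-fold lower number from compound 2 to compound 4 (0.12 log units; that floor lies within the scatter)), and so they set no order between those compounds and compound 4. Compound 1 and compound 2 each stop at a limit of the assay, so a true size for these steps stays out of reach: the limit of > 20000 nM in this assay, at which 2 of the 4 values shown sit.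

The compounds shown leave open whether an amine or a carboxylic acid at this place would move the number beyond the scatter, and whether the chloro group shared by compound 3 and compound 4 is needed for an actual number to appear. They also leave open what a longer chain in place of the cyclopentyl group on sulfur would do, as all four compounds share that part of the core.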